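A few compounds are considered here, and "the series" means these few. Any claim that something is new, unique, unknown or untested is made for them only; others in the source may bear on it.

Of the compounds shown here, two have been tested in a functional assay on PC-3 cells (Homo sapiens) for cytotoxicity, read by MTT assay, with a stated time of 48 h, in the absence of a further agent; a lower number here means a stronger inhibitor, a higher number a weaker inhibitor. Compound 1 `O=C(NCc1ccccc1)c1csc(-c2c[nH]c3ccccc23)n1` returns only a limit of the assay, > 100000 nM. Compound 2 `COc1ccc(NC(=O)c2csc(-c3cn(Cc4ccc(Cl)cc4)c4ccccc34)n2)cc1` likewise returns only a limit of the assay in this assay, > 100000 nM. Among the measured compounds shown here, compound 2 therefore stands at the same place as the one other compound measured, and the shared picture is summarised by the limit of > 100000 nM in this assay, at which 2 of the 2 values shown sit. Compound 3 `O=C(Nc1ccccc1)c1csc(-c2cn(Cc3ccc(Cl)cc3)c3ccccc23)n1` is the next compound to be measured. It differs from compound 2 in one place: hydrogen in place of methoxy on an aromatic carbon. For the measured compounds named here, no measured pair shows this kind of change, so no step size can be read from the data. With both measured compounds sitting at the limit, compound 3 is expected to show a step of a number no higher from compound 2 to compound 3 (the limit leaves the size open), none beyond the scatter. Compound 3 is estimated at 100000 nM, within 25000 nM to 400000 nM, most likely reported again as a limit.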

Compound 3, half-maximal inhibitory concentration: 76400 nM
Compound 3: middle estimate off by 1.3-fold (0.12 log units), on the high side; low and high end bracket the measured number.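

In this assay, among the compounds shown here, compound 3 gives 76400 nM, the first value of the series that is a number and not a limit. Hydrogen in place of methoxy on an aromatic carbon, para to a large group, gives an at least 1.3-fold lower number from compound 2 to compound 3 (0.11 log units; that floor lies within the scatter), so the removal of methoxy at this place at least leaves a readable value, although it cannot be called a gain in strength. From the compounds shown here alone, compound 2 gives only a limit of the assay, > 100000 nM, so the true size of the step stays unknown.

Going by these compounds, the picture of the series as a whole still rests largely on a limit: the limit of > 100000 nM in this assay, at which 2 of the 3 values shown sit. Whether a fluorine, a hydroxyl or an amine at this place on the phenyl ring would give a number different from that of compound 3 remains open.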